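A few compounds are considered here, and "the series" means these few. Any claim that something is new, unique, unknown or untested is made for them only; others in the source may bear on it.

Measured so far in an assay on COS-7 cells for inhibition of patatin-like phospholipase domain-containing protein 2 (Mus musculus); a lower number here means a stronger inhibitor, a higher number a weaker inhibitor:
compound 1 `CCOC(=O)c1cccc(-c2ccc(O)cc2)c1` gives 100000 nM
compound 2 `CCOC(=O)c1cccc(-c2ccc(OCC)nc2)c1` gives 130000 nM
compound 3 `CCOC(=O)c1cccc(-c2cccs2)c1` gives 90000 nM

All three numbers sit in the same region. Compound 1 is not set apart from either neighbour: its gap to compound 3 and its gap to compound 2 both lie within the usual scatter of repeated measurements, so none of the three can be called stronger or weaker than another on these data. The shared core of compound 1, the ester-bearing biaryl, carries a hydroxy on the second ring; compound 2 replaces that ring with a pyridine bearing an ethoxy group, and compound 3 carries a thiophene, and neither swap moves the number beyond the scatter.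

Compound 4 `CCOC(=O)c1cccc(-c2ccc(CN(C)C)cc2)c1` is not yet measured. It differs from compound 1 as follows: (dimethylamino)methyl in place of hydroxy on an aromatic carbon. Within the data shown here, no pair of measured compounds differs in one place, so no step is available to scale this change; the only guide is that the three ring changes already seen leave the number where it was. The expected step from compound 1 to compound 4 is therefore no change at the digits printed from compound 1 to compound 4 (within the scatter), none beyond the scatter in either direction. Compound 4 is estimated at 100000 nM, with a range from 30000 nM to 300000 nM.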

Compound 4, half-maximal inhibitory concentration: 150000 nM
Estimate against measurement, compound 4: 1.5-fold (0.18 log units) below, and the stated range covers the measured number.
By their numbers in this assay, from the lowest: compounds 3, 1, 2 and 4 (each within the scatter of the next).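

Among these compounds, the first one-place comparison in this assay is (dimethylamino)methyl in place of hydroxy on an aromatic carbon, para to a large group, and it reads a 1.5-fold higher number from compound 1 to compound 4 (0.18 log units; within the scatter). At this position, the hydroxy with its hydrogen-bond donor can therefore be exchanged for a larger group without a hydrogen-bond donor, with no step beyond the scatter. No supporting evidence bears on how this exchange acts on the number.

The compounds shown leave open whether any group at this position can move the number beyond the scatter, as all four values remain within the scatter of their neighbours in the ranking. A carboxylic acid in place of the ethyl ester, or a primary amine in place of the (dimethylamino)methyl, remains to be compared with the shared core.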